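Fluoro for Sulfamoyl: a Step Toward Weaker Inhibition Expected

The source may hold more compounds than are shown below. What is called first, only, known or untested is meant among the compounds shown, and "the series" means these compounds.

Among the measured compounds shown here, compound 2 `Cc1cnc(Nc2ccc(S(N)(=O)=O)cc2)nc1Nc1nc2ccccc2s1` gives 2800 nM in a functional assay on HeLa cells (Homo sapiens) for antiproliferative activity, read by MTT assay, with a stated time of 48 h (on this read-out lower numbers stand for stronger inhibition and higher numbers for weaker inhibition), the lowest of the three numbers so far. In this assay compound 3 `Cc1ccc2nc(Nc3nc(Nc4ccc(S(N)(=O)=O)cc4)ncc3C)sc2c1` gives 3280 nM, and the step of a 1.2-fold higher number from compound 2 to compound 3 (0.07 log units; within the scatter) means compound 2 and compound 3 cannot be told apart. In this assay compound 1 `Cc1cnc(Nc2ccc([N+](=O)[O-])cc2)nc1Nc1nc2ccccc2s1` gives 34300 nM, and the step of a 12-fold lower number from compound 1 to compound 2 (1.09 log units; beyond the scatter) is the one large movement in the set.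

Compound 4 `Cc1cnc(Nc2ccc(F)cc2)nc1Nc1nc2ccccc2s1` is the untested analogue. Relative to compound 2 the change is fluoro in place of sulfamoyl on an aromatic carbon. For the measured compounds named here, only the step from compound 1 to compound 2 bears on this, as it is the one measured change at the same aromatic carbon and it shows that removing the sulfamoyl group in favour of another substituent can shift the number greatly. Compound 4 is therefore expected to give a higher number in this assay, with a step of a 5.4-fold higher number from compound 2 to compound 4 (0.73 log units; beyond the scatter) that is expected to lie beyond the scatter. Compound 4 is estimated at 15000 nM, within a range of 5000 nM to 45000 nM.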

Compound 4, half-maximal inhibitory concentration: > 50000 nM
Compound 4 gave a limit, no number; the forecaster's own chance of this, stated with the estimate: 10%; middle value at least 3.3-fold (0.52 log units) away from the limit.
By their numbers in this assay, from the lowest: compounds 2 and 3 (each within the scatter of the next); then compound 1. At a limit, above all of these: compound 4.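

In this assay compound 4 gives no number, only a limit: the limit of > 50000 nM in this assay, at which 1 of the 4 values shown sits. Fluoro in place of sulfamoyl brings an at least 17-fold higher number from compound 2 to compound 4 (1.25 log units; beyond the scatter), so a second replacement of sulfamoyl on this aromatic carbon, after nitro in compound 1, also goes with a large move to weaker inhibition. The two replacements cannot be ranked, since the comparison gives only an at least 1.4-fold higher number from compound 1 to compound 4 (0.16 log units; that floor lies within the scatter), and that floor does not separate fluoro from nitro.

The compounds shown leave open whether sulfamoyl is the only group on this carbon that gives numbers as low as those of compound 2 and compound 3. An amine, a carboxylic acid or a carboxamide in the same place could hold the number there or lose it, and the data shown do not say which.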